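The compounds below may be only part of what the source reports. "The series", "measured", "known", "first", "only" and "open" are said of these compounds alone.

Measured compounds:
Compound 1 `COc1ccc(/C=N/NC(=O)Nc2ccc(Oc3ccnc(-c4nncn4CCN(C)C)c3)c(F)c2)c(OC)c1OC`: in a functional assay on HT-29 cells (Homo sapiens) for cytotoxicity, read by MTT assay, with a stated time of 72 h (a lower number here means a stronger inhibitor, a higher number a weaker inhibitor), compound 1 gives 3970 nM.
Compound 2 `CN(C)CCn1cnnc1-c1cc(Oc2ccc(NC(=O)N/N=C/c3ccc(F)cc3F)cc2F)ccn1`: in this assay compound 2 gives 960 nM.
Compound 3 `CN(C)CCn1cnnc1-c1cc(Oc2ccc(NC(=O)N/N=C/c3ccc(O)c(O)c3)cc2F)ccn1`: in this assay compound 3 gives 1890 nM.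

Compound 3 stands second highest of the three numbers. The step of a 2.0-fold higher number from compound 2 to compound 3 (0.29 log units; within the scatter) lies within the scatter, whereas a 2.1-fold lower number from compound 1 to compound 3 (0.32 log units; beyond the scatter) lies beyond it; the 2,3,4-trimethoxyphenyl compound is the weakest of the three on the numbers shown, with a 4.1-fold lower number from compound 1 to compound 2 (0.62 log units; beyond the scatter) also beyond the scatter.

Compound 4 `CN(C)CCn1cnnc1-c1cc(Oc2ccc(NC(=O)N/N=C/c3ccc(F)cc3Cl)cc2F)ccn1` has not yet been measured in this assay. The change from compound 3 is 2-chloro-4-fluorophenyl in place of 3,4-dihydroxyphenyl on a carbon with a double bond to nitrogen.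

The step that bears most directly is a 2.0-fold higher number from compound 2 to compound 3 (0.29 log units; within the scatter): it exchanges a phenyl bearing two fluorines for the 3,4-dihydroxyphenyl and stays within the scatter. Compound 4 reverses that kind of exchange, bringing in a phenyl bearing one fluorine and one chlorine in place of the two hydroxyls. Both halogen-bearing and hydroxyl-bearing aryls sit below the trimethoxy aryl of compound 1 by modest margins, so no large movement is indicated. Compound 4 is therefore expected to land near compound 2, a step of a 1.9-fold lower number from compound 3 to compound 4 (0.28 log units; within the scatter) that may well fall within the scatter. Compound 4 is estimated at 1000 nM, between 400 nM and 2500 nM.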

Compound 4, half-maximal inhibitory concentration: 510 nM
The estimate for compound 4 lay 2.0-fold (0.29 log units) above the measured number; measured number inside the range.
By their numbers in this assay, from the lowest: compounds 4, 2 and 3 (each within the scatter of the next, the first and the last beyond it); then compound 1.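

In this assay the group on a carbon with a double bond to nitrogen now moves the number beyond the scatter relative to the 3,4-dihydroxyphenyl: 2-chloro-4-fluorophenyl in its place gives (a 3.7-fold lower number from compound 3 to compound 4 (0.57 log units; beyond the scatter)), whereas the 2,4-difluorophenyl of compound 2 stayed within the scatter of compound 3. Chloro in place of fluoro on an aromatic carbon does not separate the two halogen-bearing compounds (a 1.9-fold lower number from compound 2 to compound 4 (0.27 log units; within the scatter)), so compound 2 and compound 4 read as one level, and the 2,3,4-trimethoxyphenyl compound now lies further off (a 7.8-fold lower number from compound 1 to compound 4 (0.89 log units; beyond the scatter)), the widest span seen at this position. Nothing at hand accounts for these differences.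

The compounds shown leave open whether a phenyl carrying a single chloro, a bromo or a trifluoromethyl would stay at the level of compound 2 and compound 4, and so whether the halogens are needed as a pair. Also open, on these data alone, is how this position would read with an amine or a carboxylic acid on the phenyl, or with a saturated cyclohexyl ring in place of the aromatic ring.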